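Amide series: half-life after cyclohexyl for difluorophenyl

The source may hold more compounds than are shown below. What is called first, only, known or untested is meant among the compounds shown, and "the series" means these compounds.

Measured so far in an ADME assay on microsomes from liver (Homo sapiens) for metabolic stability; on this read-out lower numbers stand for a shorter-lived compound and higher numbers for a longer-lived compound: compound 1 `Cc1cccc(NC(=O)c2nn(C)c(-c3ccc(F)cc3)c2C)n1`, 1.37 h; compound 2 `Cc1cccc(NC(=O)c2nn(C)c(-c3ccc(F)cc3F)c2C)n1`, 1.12 h.

Compound 2 stands lowest of the two numbers, with compound 1 nearest; the step of a 1.2-fold lower number from compound 1 to compound 2 (0.09 log units; within the scatter) is a single fluoro swap. Compound 3 `Cc1cccc(NC(=O)c2nn(C)c(C3CCCCC3)c2C)n1` differs from compound 2 by cyclohexyl in place of 2,4-difluorophenyl on an aromatic carbon. For the measured compounds named here, no measured step exchanges the whole ring, so the fluoro step gives no guide to this change. Compound 3 is therefore expected to sit near compound 2, a step of a 1.0-fold lower number from compound 2 to compound 3 (0.01 log units; within the scatter) of no size beyond the scatter, with wide uncertainty. For compound 3 the estimate in this assay is 1.1 h, ranging from 0.4 h to 3 h.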

Compound 3, half-life: 1.38 h
The estimate for compound 3 lay 1.3-fold (0.10 log units) below the measured number; low and high end bracket the measured number.
By their numbers in this assay, from the lowest: compounds 2, 1 and 3 (each within the scatter of the next).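

In this assay, for the compounds shown here, the step of a 1.2-fold higher number from compound 2 to compound 3 (0.09 log units; within the scatter) and the step of a 1.0-fold higher number from compound 1 to compound 3 (0.00 log units; within the scatter) both lie within the scatter, the first change at this position that replaces the whole ring. On an aromatic carbon of the five-membered ring, a non-aromatic cyclohexyl ring thus reads the same as either fluorinated phenyl ring. Nothing at hand accounts for this result.

Still open, as far as these compounds go, is whether a group of another kind here, such as an amine, a carboxylic acid or a longer chain, would move the half-life beyond the scatter.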